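The compounds below may be only part of what the source reports. "The series", "measured", "known", "first", "only" and "open" are said of these compounds alone.

Compound 1 `CO/N=c1\[nH]cnc2c1[n+](C/C=C(\C)CC/C=C(\C)CC/C=C(\C)CCC=C(C)C)cn2Cc1ccccc1` and compound 2 `CO/N=c1\[nH]cnc2c1[n+](C/C=C(\C)CC/C=C(\C)CC/C=C(\C)CCC=C(C)C)cn2C(c1ccccc1)c1ccccc1` share a core that carries a charge; compound 3 `CO/N=c1\[nH]cnc2ncn(C/C=C(\C)CC/C=C(\C)CC/C=C(\C)CCC=C(C)C)c12` and compound 4 `CC(C)=CCC/C(C)=C/CC/C(C)=C/CC/C(C)=C/Cn1cnc2nc[nH]/c(=N\OCc3ccccc3)c21` share a different, uncharged core, and how the two cores differ is not broken down here. In a functional assay on U-937/GTB cells (Homo sapiens) for cytotoxicity (a higher number here means a weaker inhibitor, a lower number a stronger inhibitor), compound 1 gives 1070 nM and compound 2 gives 1970 nM, so that a 1.8-fold higher number from compound 1 to compound 2 (0.27 log units; within the scatter), the change being (phenyl in place of hydrogen on a saturated chain carbon bound to an aromatic carbon and an aromatic nitrogen). In this assay compound 3 gives 3310 nM. Compound 4 carries the same kind of change, (phenyl in place of hydrogen on a saturated chain carbon bound to an oxygen), but the place is not the same: in the earlier pair the carbon is bound to an aromatic carbon and an aromatic nitrogen, here it is bound to an oxygen. Going by the values given here, from the one precedent, a 1.8-fold higher number from compound 1 to compound 2 (0.27 log units; within the scatter), a step of similar size is expected, a 1.7-fold higher number from compound 3 to compound 4 (0.22 log units; within the scatter), with wide uncertainty. Compound 4 is thus estimated at 5500 nM in this assay, between 2500 nM and 12000 nM.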

Compound 4, half-maximal inhibitory concentration: 11200 nM
Estimate against measurement, compound 4: 2.0-fold (0.31 log units) below; measured number inside the range.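

In this assay the change from methoxy to benzyloxy gives a 3.4-fold higher number from compound 3 to compound 4 (0.53 log units; beyond the scatter) and so lies beyond the scatter, while the earlier phenyl-for-hydrogen step on the charged core gives a 1.8-fold higher number from compound 1 to compound 2 (0.27 log units; within the scatter) and lies within it. Set side by side, the two steps do not differ by more than the scatter allows: the same change on two cores in this assay, a 1.8-fold higher number (0.27 log units; within the scatter) from compound 1 to compound 2 and a 3.4-fold higher number (0.53 log units; beyond the scatter) from compound 3 to compound 4, 1.8-fold (0.26 log units) apart, within the scatter of two such steps. This shows both steps running towards a higher number, but it rests on one pair of steps at different places, so the effect of the core cannot be separated from that of the place.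

The compounds shown leave open how an ethoxy group or a longer chain on the oxygen would read in this assay. Also open, going by these compounds, is the effect of an amine or a carboxylic acid on the phenyl ring.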